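A Methoxy Group Added to Compound 2

The source may report more compounds than this note shows. Statements on the series, on what has been measured and on what is new or still open speak of the compounds shown alone.

In a functional assay on LoVo cells (Homo sapiens) for inhibition, read by colorimetric assay and MTT assay, with a stated time of 72 h (on this read-out lower numbers stand for stronger inhibition and higher numbers for weaker inhibition), compound 1 `Cn1c2cnc1OCCCCCCCCCCOc1ccccc1-2` gives 33000 nM and compound 3 `COc1ccc(C)cc1-c1cnc(OCCCCc2ccccc2)n1C` gives 27000 nM while compound 2 `C=CCCCCOc1ccccc1-c1cnc(OCCC=C)n1C` gives 12000 nM as the lowest of the three numbers. Compound 2 therefore stands below both of the others, by more than the usual scatter.

Compound 4 `C=CCCCCOc1ccc(OC)cc1-c1cnc(OCCC=C)n1C` differs from compound 2 by a single change (methoxy in place of hydrogen on an aromatic carbon) with methoxy in place of hydrogen on an aromatic carbon. Among the measured compounds shown here, no pair of measured compounds isolates this change. Compound 3 also carries a methoxy group and gives 27000 nM in this assay but it differs from compound 2 in other places too, so it offers only weak guidance. A small weakening is expected, and a 1.3-fold higher number from compound 2 to compound 4 (0.10 log units; within the scatter) is the estimated step, one expected to stay within the scatter. For compound 4 the estimate in this assay is 15000 nM and the expected range runs from 6000 nM to 35000 nM on this read-out.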

Compound 4, half-maximal inhibitory concentration: 33000 nM
For compound 4 the middle estimate is 2.2-fold (0.34 log units) below the measured one; measured number inside the range.
By their numbers in this assay, from the lowest: compound 2; then compounds 3, 1 and 4 (each within the scatter of the next).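

In this assay, methoxy in place of hydrogen on the aromatic carbon para to the (hex-5-en-1-yl)oxy group gives a 2.8-fold higher number from compound 2 to compound 4 (0.44 log units; beyond the scatter), a modest loss of inhibition that lies beyond the scatter. Among the compounds shown here, the earlier compounds held no pair differing in one place, so this is the first direct reading of a single change among them, and it shows that this carbon does not take methoxy without a cost. No measurement at hand accounts for the loss.

From the compounds shown here alone, whether the loss belongs to methoxy itself or would come with any group at this carbon stays open; a fluorine or a methyl here would separate the two. Also open, going by these compounds, is whether the step would hold for methoxy on another carbon of that ring, or with a longer chain in place of the (hex-5-en-1-yl)oxy group.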